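Amine substituent swap: pyrazole back to a substituted phenyl

The source may report more compounds than this note shows. Statements on the series, on what has been measured and on what is new or still open speak of the compounds shown alone.

Within the data shown here, compound 3 `COc1ncc(-c2ccc3ncnc(Nc4cnn(CCCO)c4)c3c2)cc1NS(=O)(=O)c1ccc(F)cc1F` gives 4830 nM in a functional assay on A549 cells (Homo sapiens) for antiproliferative activity, read by sulforhodamine B assay, with a stated time of 72 h (a lower number here means a stronger inhibitor, a higher number a weaker inhibitor), and stands second highest of the three numbers measured so far. Its nearest neighbour is compound 2 `COc1ncc(-c2ccc3ncnc(Nc4cnn(CC(=O)O)c4)c3c2)cc1NS(=O)(=O)c1ccc(F)cc1F`, which in this assay gives 5200 nM; the furthest is compound 1 `COc1ncc(-c2ccc3ncnc(Nc4ccc(OCCO)cc4)c3c2)cc1NS(=O)(=O)c1ccc(F)cc1F`, which gives 2690 nM. All three pairwise steps stay within the scatter: a 1.9-fold higher number from compound 1 to compound 2 (0.29 log units; within the scatter), a 1.8-fold higher number from compound 1 to compound 3 (0.25 log units; within the scatter) and a 1.1-fold lower number from compound 2 to compound 3 (0.03 log units; within the scatter).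

Compound 4 `COc1cc(Nc2ncnc3ccc(-c4cnc(OC)c(NS(=O)(=O)c5ccc(F)cc5F)c4)cc23)ccc1OCCO` is not yet measured. The change is 4-(2-hydroxyethoxy)-3-methoxyphenyl in place of 1-(3-hydroxypropyl)-1H-pyrazol-4-yl on a nitrogen on an aromatic ring. Among the measured compounds shown here, the entering group differs from the 4-(2-hydroxyethoxy)phenyl of compound 1 only by the methoxy carried in its name, so the step from compound 1 to compound 3 is the relevant precedent, run in reverse; it was within the scatter, and the methoxy has no precedent. A small step back toward the number of compound 1 is therefore expected, a 1.8-fold lower number from compound 3 to compound 4 (0.25 log units; within the scatter), not beyond the scatter. Compound 4 is estimated at 2700 nM, with a range from 900 nM to 8000 nM.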

Compound 4, half-maximal inhibitory concentration: 3760 nM
For compound 4 the middle estimate is 1.4-fold (0.14 log units) below the measured one; low and high end bracket the measured number.
By their numbers in this assay, from the lowest: compounds 1, 4, 3 and 2 (each within the scatter of the next).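

Notes on the group on a nitrogen on an aromatic ring: in this assay, exchanging the pyrazole groups for 4-(2-hydroxyethoxy)-3-methoxyphenyl gives no separation from either one (a 1.3-fold lower number from compound 3 to compound 4 (0.11 log units; within the scatter); a 1.4-fold lower number from compound 2 to compound 4 (0.14 log units; within the scatter)). The methoxy is the first change made on the phenyl group itself, and methoxy in place of hydrogen on an aromatic carbon also stays inside the scatter (a 1.4-fold higher number from compound 1 to compound 4 (0.15 log units; within the scatter)), so no step among these four compounds yet shows a dependence on this group. No measurement at hand bears on why the numbers lie so close together.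

From the compounds shown here alone, whether a dimethylamino chain or a morpholine in place of the 2-hydroxyethoxy would move the number beyond the scatter remains open. Also open, going by these compounds, is whether a longer chain on the phenyl group would do so.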